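The source may hold more compounds than are shown below. What is called first, only, known or untested is meant among the compounds shown, and "the series" means these compounds.

Compound 1 `C[C@@]1(c2cc(NC(=O)c3cnc(OCF)cn3)ccc2F)C=C(CF)OC(N)=N1` - 34.4 mL/min/kg
Compound 2 `C[C@@]1(c2cc(NC(=O)c3coc(C(F)F)n3)ccc2F)C=C(CF)OC(N)=N1` - 28.4 mL/min/kg

In an ADME assay on the whole organism (strain Sprague-Dawley) for pharmacokinetics, with Rattus norvegicus as the target, read by LC-MS, using cassette dosing, at a dose of 0.5 mg/kg by the intravenous route (a higher number here means faster removal of the compound, a lower number slower removal), compound 2 at 28.4 mL/min/kg sits within the usual scatter of compound 1. Compound 3 `COc1cnc(C(=O)Nc2ccc(F)c([C@]3(C)C=C(CF)OC(N)=N3)c2)cn1` has not been measured. It carries 5-methoxypyrazin-2-yl in place of 2-(difluoromethyl)-1,3-oxazol-4-yl on a carbonyl carbon. For the measured compounds named here, the one measured step that bears on this, a 1.2-fold lower number from compound 1 to compound 2 (0.08 log units; within the scatter), exchanged that same oxazole group with 5-(fluoromethoxy)pyrazin-2-yl and stayed within the scatter. Going by the values given here, no measured step covers the methoxy group itself, so no change beyond the scatter is expected, and the estimated step is a 1.2-fold higher number from compound 2 to compound 3 (0.09 log units; within the scatter) here. Compound 3 is expected near 35 mL/min/kg, within a range from 19 mL/min/kg to 62 mL/min/kg as estimated.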

Compound 3, clearance: 64.9 mL/min/kg
The estimate for compound 3 lay 1.9-fold (0.27 log units) below the measured number; the measured number lies above the stated range.
By their numbers in this assay, from the lowest: compounds 2, 1 and 3 (each within the scatter of the next, the first and the last beyond it).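

Unlike the earlier swap at this place on the carbonyl carbon, 5-methoxypyrazin-2-yl in place of 2-(difluoromethyl)-1,3-oxazol-4-yl gives a step beyond the scatter in this assay: a 2.3-fold higher number from compound 2 to compound 3 (0.36 log units; beyond the scatter). Hydrogen in place of fluoro on the chain of the pyrazine group, with a 1.9-fold higher number from compound 1 to compound 3 (0.28 log units; within the scatter), stays within the scatter, so compound 1 and compound 3 cannot be told apart. No evidence here explains the size of either step.

The ring and its substituent change together from compound 2 to compound 3, so their shares remain unseparated. Also open, from the compounds shown here alone, is how an ethoxy chain or an amine in place of the methoxy group would read.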